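Removing a chloro group: two compounds, one kind of change

A few compounds are considered here, and "the series" means these few. Any claim that something is new, unique, unknown or untested is made for them only; others in the source may bear on it.

Compound 1 `COc1ccc(-c2nc(C)c(C(=O)CSc3nc(N)c(C#N)c(-c4ccc(Cl)cc4)n3)s2)cc1` and compound 2 `COc1ccc(-c2nc(C)c(C(=O)CSc3nc(N)c(C#N)c(-c4ccccc4)n3)s2)cc1` share one core; compound 3 `Cc1nc(-c2ccc(Cl)cc2)sc1C(=O)CSc1nc(-c2ccc(Cl)c(Cl)c2)c(C#N)c(=O)[nH]1` and compound 4 `Cc1nc(-c2ccc(Cl)cc2)sc1C(=O)CSc1nc(-c2cccc(Cl)c2)c(C#N)c(=O)[nH]1` share another, and the difference between the two cores is not broken down here. In a functional assay on U-87MG ATCC cells for antiproliferative activity against U-87 MG (Homo sapiens), read by MTT assay, with a stated time of 48 h, tested at 5 uM (on this read-out lower numbers stand for a stronger effect and higher numbers for a weaker effect at the one concentration tested), compound 1 gives 51.4% and compound 2 gives 61.8%, a step of a number 10.4 percentage points higher from compound 1 to compound 2 (beyond the scatter) brought about by hydrogen in place of chloro on an aromatic carbon. Compound 3 gives 101% in this assay, the highest of the three numbers. Compound 4 carries the same kind of change, (hydrogen in place of chloro on an aromatic carbon), although here the place is ortho to a chloro group as well as para to a large group. Because compound 3 already sits at 101%, little room remains for a further weakening, so the expected step is a number 1 percentage points higher from compound 3 to compound 4 (within the scatter), smaller than the earlier one. Compound 4 is therefore estimated at 102% in this assay, expected between 90% and 114%.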

Compound 4, a percentage reported as activity, at one concentration (the size of the read-out at that concentration, not a potency): 80.2%
Estimate against measurement, compound 4: 21.8 percentage points above, outside the stated range (below it).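

In this assay the new result is a number 20.8 percentage points lower from compound 3 to compound 4 (beyond the scatter), so on this core, replacing a chloro group with hydrogen gives a stronger effect, whereas on the core of compound 1 it gives a weaker one, and the two steps disagree: the same change on two cores in this assay, a number 10.4 percentage points higher (beyond the scatter) from compound 1 to compound 2 and a number 20.8 percentage points lower (beyond the scatter) from compound 3 to compound 4, 31.2 percentage points apart, beyond the scatter of two such steps. In this series, then, the result of this change on one core cannot be assumed to carry over to another, in either size or direction. For the compounds shown here, with only one pair on each core, these results do not show why the steps differ or which difference between the cores matters.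

The compounds shown leave open what a fluoro group or an amine in place of that chloro group would do on each core. They also leave open whether further pairs on these cores would repeat the opposite directions.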